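This account rests on a few compounds, and the source may have more. Where it says the series, first, only, none or still open, it means among the compounds named here.

Compound 2, `COc1cccc(S(=O)(=O)c2cnc3ccc(F)cc3c2N2CCC(C)CC2)c1`, stands second highest of the three numbers in an assay on isolated protein for displacement of a labelled ligand from metabotropic glutamate receptor 5 (Homo sapiens), with a stated time of 60 min, tested at 1 uM; a higher number here means more inhibition at the concentration tested (going by the name of the read-out), a lower number less inhibition; compound 2 gives 90%. Compound 1, `CC1CCN(c2c(S(=O)(=O)c3ccc(Cl)c(Cl)c3)cnc3ccc(F)cc23)CC1`, lies nearest to it: compound 1 gives 91%, a gap within the scatter. Furthest away is compound 3, `COc1cccc(S(=O)(=O)c2cnc3ccc(OC)cc3c2N2CCC(C)CC2)c1`, and compound 3 gives 0%. Compound 4, `CC1CCN(c2c(S(=O)(=O)c3ccccc3)cnc3ccc(F)cc23)CC1`, has not yet been measured in this assay. It differs from compound 2 in one place: hydrogen in place of methoxy on an aromatic carbon. The measured step that bears on this change is the one at the sulfonyl aryl, a number 1 percentage points lower from compound 1 to compound 2 (within the scatter), a step within the scatter although it exchanged a 3,4-dichlorophenyl for a 3-methoxyphenyl. The other known step, a number 90 percentage points lower from compound 2 to compound 3 (beyond the scatter), sits on an aromatic carbon of the shared core and says nothing about the sulfonyl aryl. With one change at the sulfonyl aryl having left the number unmoved, the step to compound 4 is expected to be small: a number 5 percentage points lower from compound 2 to compound 4 (within the scatter). Compound 4 is therefore expected to give about 85% in this assay, estimated to fall between 60% and 96%.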

Compound 4, a percentage reported as inhibition, at one concentration (the size of the read-out at that concentration, not a potency): 40%
Compound 4: the middle estimate sits 45 percentage points above what was measured; measured number below the stated range.
By their numbers in this assay, from the lowest: compound 3; then compound 4; then compounds 2 and 1 (each within the scatter of the next).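

In this assay the sulfonyl aryl turns out not to be indifferent to what it carries: hydrogen in place of methoxy gives a number 50 percentage points lower from compound 2 to compound 4 (beyond the scatter), and phenyl in place of 3,4-dichlorophenyl gives a number 51 percentage points lower from compound 1 to compound 4 (beyond the scatter). The earlier exchange of one substituted ring for another, a number 1 percentage points lower from compound 1 to compound 2 (within the scatter), had concealed this, since only the bare phenyl of compound 4 separates from the two substituted rings. Nothing measured here gives a reason for this loss.

The compounds shown leave open whether a methyl, a hydroxyl or an amine on that aromatic carbon, meta to a large group, would bring the number back towards that of compound 2 at 90%. They also leave open whether a single chlorine would serve as well as the pair in compound 1.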